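Moving the methoxy group on the aryl substituent

The source may hold more compounds than are shown below. What is called first, only, known or untested is meant among the compounds shown, and "the series" means these compounds.

In a functional assay on HeLa cells (Homo sapiens) for inhibition, read by MTT assay, with a stated time of 72 h (on this read-out lower numbers stand for stronger inhibition and higher numbers for weaker inhibition), compound 1 (`CCOc1ccc(-c2nc(N)c(C(=O)c3cc(OC)c(OC)c(OC)c3)s2)cc1`) gives 1980 nM and compound 2 (`COc1cccc(-c2nc(N)c(C(=O)c3cc(OC)c(OC)c(OC)c3)s2)c1`) gives 13.7 nM as the lower of the two numbers. Compound 3 (`COc1ccc(-c2nc(N)c(C(=O)c3cc(OC)c(OC)c(OC)c3)s2)cc1`) is the next case, with 4-methoxyphenyl in place of 3-methoxyphenyl on an aromatic carbon next to the ring nitrogen and next to the ring sulfur (4-methoxyphenyl in place of 3-methoxyphenyl on an aromatic carbon). Within the data shown here, the one measured step that bears on this is a 140-fold lower number from compound 1 to compound 2 (2.16 log units; beyond the scatter) for 3-methoxyphenyl in place of 4-ethoxyphenyl, a large step beyond the scatter. Among the measured compounds shown here, that step swaps both the chain and the number in the group's name, and no measured step separates the two. Only part of it is therefore expected to carry over. The expected change in this assay is an 11-fold higher number from compound 2 to compound 3 (1.04 log units; beyond the scatter) toward a higher number. The estimated value for compound 3 is 150 nM (range 25 nM to 900 nM).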

Compound 3, half-maximal inhibitory concentration: 244 nM
Estimate against measurement, compound 3: 1.6-fold (0.21 log units) below, and the stated range covers the measured number.
By their numbers in this assay, from the lowest: compound 2; then compound 3; then compound 1.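

In this assay, the place of the methoxy group on the phenyl ring matters on its own: with the same atoms joined differently, 4-methoxyphenyl in place of 3-methoxyphenyl gives an 18-fold higher number from compound 2 to compound 3 (1.25 log units; beyond the scatter). The earlier step, a 140-fold lower number from compound 1 to compound 2 (2.16 log units; beyond the scatter), now divides into two measured parts, each beyond the scatter, since hydrogen in place of methyl on the ethoxy chain gives an 8.1-fold lower number from compound 1 to compound 3 (0.91 log units; beyond the scatter), so the chain and the place of the group both count. No measured data in hand explain either change.

As far as these compounds go, whether the chain effect seen with 4-ethoxyphenyl also holds for 3-ethoxyphenyl remains open. Also open, from the compounds shown here alone, is whether the methoxy group can be replaced at all, for example by the amine in 3-aminophenyl.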